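Hydroxylated Side Chains on a Shared Core

The source may report more compounds than this note shows. Statements on the series, on what has been measured and on what is new or still open speak of the compounds shown alone.

Two compounds share one core and differ only in the chain attached to the five-membered aromatic ring with 3 nitrogen. Compound 1 `OCCCCc1cn(CCNc2nonc2/C(=N/O)Nc2ccc(F)c(Br)c2)nn1` carries 4-hydroxybutyl there, and in an assay on isolated protein for inhibition of Indoleamine 2,3-dioxygenase 2 (Homo sapiens) (on this read-out lower numbers stand for stronger inhibition and higher numbers for weaker inhibition), compound 1 gives 1080 nM. Compound 2 `CCC(O)c1cn(CCNc2nonc2/C(=N/O)Nc2ccc(F)c(Br)c2)nn1` carries 1-hydroxypropyl instead, and in this assay compound 2 gives 947 nM. The step of a 1.1-fold lower number from compound 1 to compound 2 (0.06 log units; within the scatter) shows that exchanging one hydroxyalkyl chain for another barely moved the read-out. Compound 2 shows the lower of the two numbers, but its gap to compound 1 lies within the scatter, so neither compound can be called the stronger inhibitor.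

Compound 3 `OCCOCc1cn(CCNc2nonc2/C(=N/O)Nc2ccc(F)c(Br)c2)nn1` has not yet been measured. It differs from compound 2 by (2-hydroxyethoxy)methyl in place of 1-hydroxypropyl on an aromatic carbon. Going by the values given here, the one measured step bearing on this change is a 1.1-fold lower number from compound 1 to compound 2 (0.06 log units; within the scatter), which left the read-out effectively flat. Since the entering chain again carries a single hydroxyl, the expected step of a 1.1-fold higher number from compound 2 to compound 3 (0.02 log units; within the scatter) is one of no change beyond the scatter. Compound 3 is therefore expected to give 1000 nM in this assay, with a range from 450 nM to 2200 nM.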

Compound 3, half-maximal inhibitory concentration: 144 nM
Estimate against measurement, compound 3: 6.9-fold (0.84 log units) above, outside the stated range (below it).
By their numbers in this assay, from the lowest: compound 3; then compounds 2 and 1 (each within the scatter of the next).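

In this assay, the position on the aromatic carbon of the five-membered ring proved sensitive to the chain it carries: the exchange of 1-hydroxypropyl for (2-hydroxyethoxy)methyl produced a 6.6-fold lower number from compound 2 to compound 3 (0.82 log units; beyond the scatter), whereas the earlier exchange between two hydroxyalkyl chains had left the read-out flat. The comparison with the other measured chain, 2-hydroxyethoxy in place of 3-hydroxypropyl on a saturated chain carbon bound to an aromatic carbon, points the same way, with a 7.5-fold lower number from compound 1 to compound 3 (0.88 log units; beyond the scatter), so a single hydroxyl on the chain did not by itself set the read-out in these compounds. No measurement at hand accounts for this step.

The compounds shown leave open whether the step follows the oxygen inside the chain or depends on that oxygen working together with the terminal hydroxyl, a question that 5-hydroxypentyl, with carbon in place of that oxygen, or (2-methoxyethoxy)methyl, with the hydroxyl capped as a methyl ether, could settle. They also leave open how the read-out would respond to an amine or a carboxylic acid at the end of the same chain, or to a longer chain with further ether oxygens.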